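Replacing Chloro with Methoxy: What the Steps Suggest

The source may report more compounds than this note shows. Statements on the series, on what has been measured and on what is new or still open speak of the compounds shown alone.

Three compounds have been measured in a functional assay on the whole organism with Rattus norvegicus as the target, read by paw edema, with a stated time of 3 h, at a dose of 100 mg/kg by the oral route; on this read-out higher numbers stand for more inhibition at the one dose given (going by the name of the read-out) and lower numbers for less inhibition:

compound 1 `Cc1cccc(-c2nc3ccccc3[nH]2)n1`: 44%
compound 2 `OCc1cccc(-c2nc3ccccc3[nH]2)n1`: -13%
compound 3 `Clc1cccc(-c2nc3ccccc3[nH]2)n1`: 30%

Compound 3 stands second highest of the three numbers. Its nearest neighbour is compound 1, the difference being a number 14 percentage points lower from compound 1 to compound 3 (beyond the scatter). Its furthest neighbour is compound 2, the difference being a number 43 percentage points higher from compound 2 to compound 3 (beyond the scatter).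

Compound 4 `COc1cccc(-c2nc3ccccc3[nH]2)n1` differs from compound 3 in one place: methoxy in place of chloro on an aromatic carbon. Going by the values given here, three measured steps bear on this change. The swap of chloro for methyl gave a number 14 percentage points lower from compound 1 to compound 3 (beyond the scatter), a modest step. The swap of hydroxymethyl for chloro gave a number 43 percentage points higher from compound 2 to compound 3 (beyond the scatter), a large step, and adding hydroxy to the chain gave a number 57 percentage points lower from compound 1 to compound 2 (beyond the scatter), also large. Methoxy, like hydroxymethyl, brings one hydrogen-bond acceptor, but no donor, so a fall of some size, though smaller than that between compound 2 and compound 3, is expected in this assay.

Compound 4 is therefore expected to give 15% in this assay, with a range from -15% to 40%. This estimate means a step of a number 15 percentage points lower from compound 3 to compound 4 (beyond the scatter), expected to lie beyond the scatter.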

Compound 4, a percentage reported as inhibition, in the whole organism at one dose (the size of the read-out at that dose, not a potency): 47%
Estimate against measurement, compound 4: 32 percentage points below; measured number above the stated range.
By their numbers in this assay, from the lowest: compound 2; then compound 3; then compounds 1 and 4 (each within the scatter of the next).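

At this place, on an aromatic carbon next to the ring nitrogen, an oxygen in the entering group does not by itself bring a fall in this assay: methoxy in place of chloro gives a number 17 percentage points higher from compound 3 to compound 4 (beyond the scatter), and methoxy in place of hydroxymethyl gives a number 60 percentage points higher from compound 2 to compound 4 (beyond the scatter), so the low number of the hydroxymethyl compound is not shared by the other oxygen-bearing group. Methoxy in place of methyl gives a number 3 percentage points higher from compound 1 to compound 4 (within the scatter), so at this one dose the two groups cannot be told apart, and chloro and hydroxymethyl are the two groups that go with lower numbers. Nothing measured here explains why methoxy and hydroxymethyl part so widely at this position.

The compounds shown leave open whether an amine, a carboxylic acid or a longer chain such as ethoxy at this place would stay level with methyl and methoxy or fall towards hydroxymethyl. They also leave open whether the same order would hold at other doses or at other times, as each compound is represented by a single reading.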